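Lengthening the sulfonamide chain of compound 3

The source may hold more compounds than are shown below. What is called first, only, known or untested is meant among the compounds shown, and "the series" means these compounds.

For the measured compounds named here, compound 3 `CCCS(=O)(=O)Nc1ccc(F)c(C(=O)c2n[nH]c3ncc(-c4ccc(S(N)(=O)=O)cc4)cc23)c1F` gives 0.25% in an assay for binding affinity to dual specificity mitogen-activated protein kinase kinase 4 (Homo sapiens), read by KINOMEscan, tested at 100 nM (a higher number here means a weaker effect of the compound at the concentration tested, a lower number a stronger effect), the lowest of the three numbers so far. Compound 1 `CCCS(=O)(=O)Nc1ccc(F)c(C(=O)c2n[nH]c3ncc(-c4cccc(F)c4)cc23)c1F` is the nearest to it with 8.2%, and the step of a number 8 percentage points lower from compound 1 to compound 3 (within the scatter) lies within the scatter. Compound 2 `CCCS(=O)(=O)Nc1ccc(F)c(C(=O)c2n[nH]c3ncc(-c4ccc(Cl)cc4Cl)cc23)c1F` is the furthest with 22%, and the step of a number 21.8 percentage points lower from compound 2 to compound 3 (beyond the scatter) lies beyond the scatter. Compound 4 `CCCCS(=O)(=O)Nc1ccc(F)c(C(=O)c2n[nH]c3ncc(-c4ccc(S(N)(=O)=O)cc4)cc23)c1F` differs from compound 3 by methyl in place of hydrogen on a saturated chain carbon, three bonds along the chain from a sulfonyl sulfur. Going by the values given here, every measured step changes the aromatic group on the shared core, and none alters the sulfonamide chain, so no measured step bears directly on this change. He therefore expects no step beyond the scatter in this assay. For compound 4 the estimate is 0.4%, within 0.05% to 4%, meaning an expected step of a number 0.2 percentage points higher from compound 3 to compound 4 (within the scatter).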

Compound 4, a percentage reported as activity, at one concentration (the size of the read-out at that concentration, not a potency): 0.25%
Compound 4: the middle estimate sits 0.2 percentage points above what was measured; low and high end bracket the measured number.
By their numbers in this assay, from the lowest: compounds 3, 4 and 1 (each within the scatter of the next); then compound 2.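

In this assay, for the compounds shown here, the first measured change to the sulfonamide chain, propyl to butyl, gives no change at the digits printed from compound 3 to compound 4 (within the scatter). Going by these compounds alone, with the 4-sulfamoylphenyl group in place, this position therefore accepts methyl in place of hydrogen without a step beyond the scatter, whereas the earlier steps concerned only the aromatic group on the shared core. Nothing available explains this result. From the compounds shown here alone, whether a longer chain such as pentyl, or an amine at the chain end, would behave alike remains open. So does whether butyl would match propyl alongside the 3-fluorophenyl or 2,4-dichlorophenyl group.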